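Cytotoxicity notes on a biaryl amide series

The compounds below may be only part of what the source reports. "The series", "measured", "known", "first", "only" and "open" are said of these compounds alone.

Measured compounds:
Compound 1 `CCOC(=O)CCCCCOc1cccc(CN(C(=O)c2ccc(-c3ccc4ccccc4c3)cc2)C(C)C)c1`. In an ADME assay on BJ cells (Homo sapiens) for cytotoxicity, read by CellTiter-Glo and resazurin assay, with a stated time of 72 h (on this read-out lower numbers stand for an effect already at smaller amounts and higher numbers for an effect only at larger amounts of compound), compound 1 gives > 26000 nM, which is a limit of the assay.
Compound 2 `CCOC(=O)CCCCCOc1cccc(CN(C(=O)c2ccc(-c3cccc(OC(C)C)c3)cc2)C(C)C)c1`. In this assay compound 2 gives > 26000 nM, again a limit.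
Compound 3 `CCOC(=O)CCCCCOc1cccc(CN(C(=O)c2ccc(-c3cccc(-c4nnc(C)o4)c3)cc2)C(C)C)c1`. In this assay compound 3 gives > 26000 nM, also a limit.

Compound 3 thus stands where every measured member of the series stands: at the limit, with no number of its own. The three pairwise steps say as much: a step that the two limits leave unreadable from compound 1 to compound 2, a step that the two limits leave unreadable from compound 1 to compound 3 and a step that the two limits leave unreadable from compound 2 to compound 3. The common point is the limit of > 26000 nM in this assay, at which 3 of the 3 values shown sit.

The next compound is compound 4 `CCOC(=O)CCCCCOc1cccc(CN(C(=O)c2ccc(-c3cc(OC)cc(OC)c3)cc2)C(C)C)c1`. Its change from compound 3 is 3,5-dimethoxyphenyl in place of 3-(5-methyl-1,3,4-oxadiazol-2-yl)phenyl on an aromatic carbon. Among the measured compounds shown here, no measured step bears on this exchange directly, and the three that exist are unreadable, so no size or direction can be derived; none beyond the scatter is assumed.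

With all comparators at the limit, compound 4 is expected to sit there as well, estimated at 30000 nM with a range of 15000 nM to 80000 nM. The step from compound 3 is expected to be a step that the limit leaves unreadable from compound 3 to compound 4.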

Compound 4, half-maximal effective concentration: > 26000 nM
Compound 4: a limit, no number; the forecaster's own chance of this, stated with the estimate: 85%; the middle value does not contradict the limit.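

Compound 4 yields no readable step against compound 1, compound 2 or compound 3, and the series keeps one common point: the limit of > 26000 nM in this assay, at which 4 of the 4 values shown sit. The compounds shown leave open where any of these four compounds would give a number of its own in this assay, and whether the exchanged groups on the aromatic carbon differ there at all.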